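Methylsulfonyl for trifluoromethoxy: compound 3 to compound 4

The source may hold more compounds than are shown below. What is called first, only, known or untested is meant among the compounds shown, and "the series" means these compounds.

Compound 3 `O=C(c1ccccc1OC(F)(F)F)N1CCC(N(C2CC2)S(=O)(=O)c2cccc(C(F)(F)F)c2)CC1` gives 120 nM in an assay on HEK293 cells for inhibition of Voltage-dependent N-type calcium channel subunit alpha-1B (Homo sapiens), read by FLIPR and calcium flux, in the presence of a further agent that is not named here (on this read-out lower numbers stand for stronger inhibition and higher numbers for weaker inhibition), and holds the lowest of the three numbers in hand. Compound 1 `COC(=O)c1cccc(C(=O)N2CCC(N(C3CC3)S(=O)(=O)c3cccc(C(F)(F)F)c3)CC2)c1` gives 380 nM in this assay, and compound 2 `CS(=O)(=O)c1ccc(F)cc1C(=O)N1CCC(N(C2CC2)S(=O)(=O)c2cccc(C(F)(F)F)c2)CC1` gives 560 nM. The steps of a 3.2-fold lower number from compound 1 to compound 3 (0.50 log units; beyond the scatter) and a 4.7-fold lower number from compound 2 to compound 3 (0.67 log units; beyond the scatter) both lie beyond the scatter, whereas a 1.5-fold higher number from compound 1 to compound 2 (0.17 log units; within the scatter) does not.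

Compound 4 `CS(=O)(=O)c1ccccc1C(=O)N1CCC(N(C2CC2)S(=O)(=O)c2cccc(C(F)(F)F)c2)CC1` differs from compound 3 by methylsulfonyl in place of trifluoromethoxy on an aromatic carbon. The step that bears most directly on this change is a 4.7-fold lower number from compound 2 to compound 3 (0.67 log units; beyond the scatter), where the aryl on the carbonyl carbon was 5-fluoro-2-(methylsulfonyl)phenyl; compound 4 carries the 2-(methylsulfonyl)phenyl without that fluorine. Read in reverse, that step points to a higher number for compound 4, and the step of a 1.5-fold higher number from compound 1 to compound 2 (0.17 log units; within the scatter), which lies within the scatter, suggests that the methylsulfonyl-bearing and methoxycarbonyl-bearing aryls land close together. Going by the values given here, no measured pair separates the fluorine on its own, so any offset of compound 4 from compound 2 cannot be read from the data. A modest rise for compound 4 relative to compound 3 is therefore expected, a 3.8-fold higher number from compound 3 to compound 4 (0.57 log units; beyond the scatter). The estimate for compound 4 in this assay is 450 nM, with a range from 200 nM to 1100 nM.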

Compound 4, half-maximal inhibitory concentration: 660 nM
Compound 4: the middle estimate sits 1.5-fold (0.17 log units) below what was measured; the range from low to high includes it.
By their numbers in this assay, from the lowest: compound 3; then compounds 1, 2 and 4 (each within the scatter of the next).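

Notes on the aromatic carbon ortho to a large group: in this assay the direct exchange of trifluoromethoxy for methylsulfonyl gives a 5.5-fold higher number from compound 3 to compound 4 (0.74 log units; beyond the scatter) as a step beyond the scatter, so this single-group change now has its own measured size rather than one seen only with a fluorine also present on the aryl. Going by these compounds alone, the fluorine can also be read on its own for the first time: hydrogen in place of fluoro gives a 1.2-fold higher number from compound 2 to compound 4 (0.07 log units; within the scatter) and stays within the scatter, so this assay does not separate the fluorinated and unfluorinated methylsulfonyl aryls. The step of a 1.7-fold higher number from compound 1 to compound 4 (0.24 log units; within the scatter) also stays within the scatter, which means that 2-(methylsulfonyl)phenyl and 3-(methoxycarbonyl)phenyl cannot be told apart here, although they differ in both group and place on the ring.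

No measurement in hand explains the separation between trifluoromethoxy and methylsulfonyl. Still open, as far as these compounds go, is how other groups on this aromatic carbon would compare, such as methoxy, which would test the role of the fluorines in trifluoromethoxy, or a carboxylic acid or an amine.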